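The source may report more compounds than this note shows. Statements on the series, on what has been measured and on what is new or still open speak of the compounds shown alone.

Measured in a functional assay on KB cells (Homo sapiens) for antiproliferative activity; on this read-out lower numbers stand for stronger inhibition and higher numbers for weaker inhibition:
Compound 1 `COc1ccc(S(=O)(=O)N2CCc3cccc(Nc4ccc(O)cc4)c32)cc1`: 239 nM
Compound 2 `COc1ccc(S(=O)(=O)N2CCc3cccc(Nc4ccccc4)c32)cc1`: 342 nM

Among the measured compounds shown here, compound 2, at 342 nM, stands within the scatter of compound 1, the only other measured compound, so neither stands apart. Compound 3 `COc1ccc(Nc2cccc3c2N(S(=O)(=O)c2ccc(OC)cc2)CC3)cc1` differs from compound 2 by one change, methoxy in place of hydrogen on an aromatic carbon, turning phenyl into 4-methoxyphenyl. For the measured compounds named here, one measured step bears on it, the swap of hydroxy for hydrogen on an aromatic carbon, which reads a 1.4-fold higher number from compound 1 to compound 2 (0.16 log units; within the scatter). Going by the values given here, no methoxy compound has been measured yet, so the data fix no direction, and on that single step no change beyond the scatter is expected in this assay. The expected step is estimated as a 1.4-fold lower number from compound 2 to compound 3 (0.14 log units; within the scatter). For compound 3 the estimated value is 250 nM, with an expected range from 80 nM to 750 nM.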

Compound 3, half-maximal inhibitory concentration: 1200 nM
The estimate for compound 3 lay 4.8-fold (0.68 log units) below the measured number; measured number outside the range, above it.
By their numbers in this assay, from the lowest: compounds 1 and 2 (each within the scatter of the next); then compound 3.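

In this assay, turning phenyl into 4-methoxyphenyl gives a 3.5-fold higher number from compound 2 to compound 3 (0.55 log units; beyond the scatter) and so shows that this position, para to a large group, does not accept every group alike. Hydroxy and hydrogen had stayed within the scatter of each other there, and only methoxy moves the number beyond it. Methyl in place of the hydrogen on the oxygen gives a 5.0-fold higher number from compound 1 to compound 3 (0.70 log units; beyond the scatter) and so separates two oxygen-bearing groups at the same place, a difference the earlier pair could not reveal. No measurement at hand accounts for this shift.

As far as these compounds go, whether the weaker inhibition is peculiar to methoxy stays open. The compounds shown do not tell how fluorine, an amine, a carboxylic acid or a longer chain such as ethoxy would read at this position.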